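A Chlorophenyl Swap on the Higher-Reading Compound

The compounds below may be only part of what the source reports. "The series", "measured", "known", "first", "only" and "open" are said of these compounds alone.

Going by the values given here, in a functional assay on HCT-15 cells (Homo sapiens) for cytotoxicity, read by ELISA, with a stated time of 4 days (a higher number here means a weaker inhibitor, a lower number a stronger inhibitor), compound 2 `Cc1ccsc1-c1cc(-c2ccc(Cl)o2)cc(-c2ccco2)n1` gives 26300 nM, the highest of the two numbers so far, while compound 1 `Cc1ccsc1-c1cc(-c2ccoc2)cc(-c2ccco2)n1` gives 640 nM. Compound 3 `Cc1ccsc1-c1cc(-c2ccc(Cl)o2)cc(-c2cccc(Cl)c2)n1` keeps the 5-chlorofuran-2-yl group of compound 2 but carries 3-chlorophenyl in place of furan-2-yl on an aromatic carbon, next to the ring nitrogen: 3-chlorophenyl in place of furan-2-yl on an aromatic carbon. Among the compounds with values here, the only measured step, a 41-fold higher number from compound 1 to compound 2 (1.61 log units; beyond the scatter), is large, but it changed a different place and left the furan-2-yl group untouched. It shows that one exchange can move the number far, yet it gives no direction for this one. Within the data shown here, no measurement yet tests the place now being changed, so only a modest fall is expected, with wide uncertainty. The estimated change is a 2.2-fold lower number from compound 2 to compound 3 (0.34 log units; beyond the scatter). For compound 3 the expected value is 12000 nM, within an estimated range of 2500 nM to 60000 nM.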

Compound 3, half-maximal inhibitory concentration: 26400 nM
Estimate against measurement, compound 3: 2.2-fold (0.34 log units) below; the range from low to high includes it.
By their numbers in this assay, from the lowest: compound 1; then compounds 2 and 3 (each within the scatter of the next).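

With the 5-chlorofuran-2-yl group held in place, the first exchange tested on the aromatic carbon next to the ring nitrogen gives a 1.0-fold higher number from compound 2 to compound 3 (0.00 log units; within the scatter) in this assay. Going by these compounds alone, at this place, then, the assay does not separate furan-2-yl from 3-chlorophenyl, even though the two differ in ring size, in the ring oxygen and in the added chlorine, so the large step seen at the other place has no counterpart here. Nothing available explains why the two groups read alike.

As far as these compounds go, it remains open whether the same exchange would read alike beside the furan-3-yl group of compound 1. From the compounds shown here alone, it is also open whether an amine or a carboxylic acid on the phenyl ring at this place would move the number.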